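Swapping an Amide for an Alcohol on a Shared Core

The source may hold more compounds than are shown below. What is called first, only, known or untested is meant among the compounds shown, and "the series" means these compounds.

Compound 1 `Cc1cc(CCC#N)cc(C)c1Oc1cc(Nc2ccc(C#N)cc2)c(N)cc1C(N)=O`: 2.65
Compound 2 `Cc1cc(/C=C/C#N)cc(C)c1Oc1cc(Nc2ccc(C#N)cc2)c(N)cc1[N+](=O)[O-]`: > 5
Compound 3 `Cc1cc(/C=C/C#N)cc(C)c1Oc1cc(Nc2ccc(C#N)cc2)c(N)cc1C(N)=O`: 3.53

Among the compounds with values here, in a physicochemical assay for lipophilicity, at pH 7.4 (on this read-out higher numbers stand for higher lipophilicity and lower numbers for lower lipophilicity), compound 1 gives 2.65, the lowest of the two numbers reported; the only other number lies a number 0.88 log units higher from compound 1 to compound 3 (beyond the scatter). For compound 2 this assay reports only a limit, > 5, and no number.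

Compound 4 `Cc1cc(CCC#N)cc(C)c1Oc1cc(Nc2ccc(C#N)cc2)c(N)cc1CO` differs from compound 1 by hydroxymethyl in place of carbamoyl on an aromatic carbon. Among the measured steps, only one touches the carbamoyl group: a number at least 1.47 log units lower from compound 2 to compound 3 (beyond the scatter). That step sets nitro against carbamoyl rather than hydroxymethyl against carbamoyl, so it fixes neither the size nor the direction of the present change with certainty. A modest rise in this assay is expected, a number 0.45 log units higher from compound 1 to compound 4 (beyond the scatter). Compound 4 is therefore estimated at 3.1, with a range from 2.6 to 3.6.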

Compound 4, partition coefficient: 3.68
Compound 4: middle estimate off by 0.58 log units, on the low side, and the stated range ends below it.
By their numbers in this assay, from the lowest: compound 1; then compounds 3 and 4 (each within the scatter of the next). At a limit, above all of these: compound 2.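

In this assay, within the data shown here, hydroxymethyl in place of carbamoyl on this aromatic carbon gives a number 1.03 log units higher from compound 1 to compound 4 (beyond the scatter), the first change at this position read as an exact number rather than against a limit of the assay. Both groups count the same hydrogen-bond donors and acceptors, so that count does not follow this rise. Nothing measured here explains the change.

The compounds shown leave open how a carboxylic acid or an aminomethyl group would read at this position. They also leave open whether this swap gives a similar step alongside the 2-cyanoethenyl group of compound 3.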